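A few compounds are considered here, and "the series" means these few. Any claim that something is new, unique, unknown or untested is made for them only; others in the source may bear on it.

Measured compounds in a functional assay on SK-N-SH cells (Homo sapiens) for inhibition, read by MTT assay, with a stated time of 72 h, tested at 30 uM; a higher number here means more inhibition of growth at the concentration tested, a lower number less inhibition of growth:
Compound 1, `C=CCc1ccc(OCc2cn(-c3ccc(C#N)cc3)nn2)c(O)c1`, gives 37.5%.
Compound 2, `C=CCc1ccc(OCc2cn(-c3ccccc3Cl)nn2)c(O)c1`, gives 10.2%.
Compound 3, `C=CCc1ccc(OCc2cn(-c3cccc(C#N)c3)nn2)c(O)c1`, gives 21.2%.

Compound 1 stands highest of the three numbers. Its lead is beyond the scatter in both directions: a number 16.3 percentage points lower from compound 1 to compound 3 (beyond the scatter), and a number 27.3 percentage points lower from compound 1 to compound 2 (beyond the scatter). Between the two lower compounds, a number 11 percentage points higher from compound 2 to compound 3 (beyond the scatter), so the three values are spread in modest, distinct steps.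

Compound 4, `C=CCc1ccc(OCc2cn(-c3ccc(C(=O)c4ccccc4)cc3)nn2)c(O)c1`, differs from compound 1 by benzoyl in place of cyano on an aromatic carbon. Among the compounds with values here, none of the measured steps touches this kind of change: all three swap the whole aryl group on the aromatic nitrogen, and none replaces a substituent on an aromatic carbon while keeping the rest in place. The measured steps therefore only show that in this small set the numbers move by modest amounts when the aryl substituent is varied, with the 4-cyanophenyl compound 1 at the top. With nothing that directly bears on a benzoyl group, compound 4 is expected to stay near compound 1, and the step of a number 4.5 percentage points lower from compound 1 to compound 4 (within the scatter) is estimated to lie within or just outside the scatter. Compound 4 is estimated at 33%, with a range from 12% to 55%.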

Compound 4, percent growth inhibition at one concentration: 41.9%
Compound 4: middle estimate off by 8.9 percentage points, on the low side; low and high end bracket the measured number.
By their numbers in this assay, from the lowest: compound 2; then compound 3; then compounds 1 and 4 (each within the scatter of the next).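

In this assay, putting benzoyl in place of cyano on the aromatic carbon para to a large group gives a number 4.4 percentage points higher from compound 1 to compound 4 (within the scatter), so the two compounds cannot be told apart here. Within the data shown here, the earlier compounds showed only that the number moved when the whole aryl group changed, as when the nitrile was found on a different ring position in compound 3 or when compound 2 carried a 2-chlorophenyl group; they did not show what happens when the substituent stays at this place and only its identity changes. Here a group of 2 heavy atoms gives way to one of 8 that brings its own six-membered aromatic ring, and the number stays within the scatter, yet nothing available explains why the two groups read alike.

The compounds shown leave open what an amine, a carboxylic acid or a longer chain at this place would give. They also leave open whether the carbonyl or the added phenyl ring of the benzoyl group matters, which a plain phenyl or an acetyl group at the same place would begin to separate.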